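The compounds below may be only part of what the source reports. "The series", "measured", "known", "first", "only" and "open" are said of these compounds alone.

Compound 3, with structure `Cc1nc(-c2ccc(Cl)cc2)sc1C(=O)CSc1nc(N)c(C#N)c(-c2ccc(Cl)cc2)n1`, is the starting point. In an assay on membranes from CHO cells for displacement of a labelled ligand from adenosine receptor A1 (Homo sapiens), read by scintillation counting, with a stated time of 60 min, tested at 1 uM (a higher number here means more inhibition at the concentration tested (going by the name of the read-out), a lower number less inhibition), compound 3 gives -3.7%. Among the three measured compounds this is the second highest number, but its nearest neighbour, compound 1 with structure `COc1ccc(-c2nc(SCC(=O)c3sc(-c4ccccc4)nc3C)nc(N)c2C#N)cc1`, gives -4.6%, which lies within the scatter, so the two cannot be told apart. Compound 2, with structure `COc1ccc(-c2nc(C)c(C(=O)CSc3nc(N)c(C#N)c(-c4ccc(OC)cc4)n3)s2)cc1`, gives 9%, and the gap from compound 3 to compound 2 lies beyond the scatter.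

Compound 4 has structure `COc1ccc(-c2nc(SCC(=O)c3sc(-c4ccc(Cl)cc4)nc3C)nc(N)c2C#N)cc1`. The change from compound 3 is methoxy in place of chloro on an aromatic carbon. Among the compounds with values here, only one measured step exists for comparison: a number 13.6 percentage points higher from compound 1 to compound 2 (beyond the scatter). That step also brings in a methoxy group on an aromatic carbon, but there it replaces hydrogen rather than chloro, and it sits on a different aryl group of the shared core, so it bears on the new step only loosely. All three measured values lie close to zero, so a methoxy entering in place of chloro is expected to move the number little, if at all: the estimated step is a number 5.7 percentage points higher from compound 3 to compound 4 (within the scatter), a small rise that is not expected to clear the scatter. Compound 4 is therefore estimated at 2%, within a range from -10% to 14%.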

Compound 4, a percentage reported as inhibition, at one concentration (the size of the read-out at that concentration, not a potency): 1.2%
Compound 4: the middle estimate sits 0.8 percentage points above what was measured; the measured number falls inside the stated range.
By their numbers in this assay, from the lowest: compounds 1, 3, 4 and 2 (each within the scatter of the next, the first and the last beyond it).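

In this assay, 4-methoxyphenyl in place of 4-chlorophenyl gives a number 4.9 percentage points higher from compound 3 to compound 4 (within the scatter), so at this position on the aryl group the two substituents cannot be told apart by this read-out. Compound 4 also adds chloro to the comparison on the other aryl group, the one where the earlier methoxy-for-hydrogen step was seen: chloro in place of methoxy gives a number 7.8 percentage points lower from compound 2 to compound 4 (within the scatter), and chloro in place of hydrogen gives a number 5.8 percentage points higher from compound 1 to compound 4 (within the scatter), so hydrogen and methoxy remain distinguishable there while chloro can be separated from neither. No measurement at hand offers an explanation for these small differences.

The compounds shown carry only chloro or methoxy at the position changed in this step, so it remains open whether the earlier result, a number 13.6 percentage points higher from compound 1 to compound 2 (beyond the scatter), would recur there with hydrogen as the starting point. Going by these compounds, it is also open whether a more different group at this position, such as an amine or a carboxylic acid, would move the number clear of the scatter.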